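This account rests on a few compounds, and the source may have more. Where it says the series, first, only, none or still open, it means among the compounds named here.

Measured compounds:
compound 1 `COc1cc(NC(=O)c2csc(-c3c[nH]c4ccc(Br)cc34)n2)cc(OC)c1OC`: > 100000 nM
compound 2 `O=C(Nc1ccccc1)c1csc(-c2cn(Cc3ccc(Cl)cc3)c3ccccc23)n1`: > 100000 nM

In a functional assay on LNCaP C4-2 cells (Homo sapiens) for cytotoxicity, read by MTT assay, with a stated time of 48 h, in the presence of a further agent that is not named here (a higher number here means a weaker inhibitor, a lower number a stronger inhibitor), compound 1 gives only a limit, > 100000 nM. In this assay compound 2 likewise gives only a limit, > 100000 nM. Neither result is a number, so the two compounds cannot be set in order against each other; both sit at the limit of > 100000 nM in this assay, at which 2 of the 2 values shown sit. Compound 2 is the starting point of the step considered here.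

The unmeasured compound 3 `COc1cc(NC(=O)c2csc(-c3cn(Cc4ccc(Cl)cc4)c4ccccc34)n2)cc(OC)c1OC` differs from compound 2 in one place: 3,4,5-trimethoxyphenyl in place of phenyl on an amide-type nitrogen. For the measured compounds named here, the 3,4,5-trimethoxyphenyl on the amide-type nitrogen also occurs in compound 1, which sits at the limit too, though compound 1 and compound 3 differ elsewhere as well, and no step between them is counted. Going by the values given here, no step between measured compounds is available, so the size of the change in this assay is open. With both measured compounds at the limit, the expectation is that compound 3 also reports no number. Compound 3 is estimated at 120000 nM, with a range from 30000 nM to 500000 nM. The expected step that the limit leaves unreadable from compound 2 to compound 3 is none beyond the scatter, pending the measurement.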

Compound 3, half-maximal inhibitory concentration: > 100000 nM
Compound 3: only a limit was reported; the forecaster's own chance of this, stated with the estimate: 80%; the middle value is on the limit's open side.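

In this assay compound 3 gives only a limit of > 100000 nM and no number. Compound 2 is also only a limit, so no step can be read from compound 2 to compound 3. The compounds shown leave open whether 3,4,5-trimethoxyphenyl in place of phenyl on the amide-type nitrogen changes the read-out at all.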